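The compounds below may be only part of what the source reports. "The series", "measured", "known", "first", "only" and "open" are said of these compounds alone.

Compound 1 `O=c1ccn(CCOc2ccccc2Oc2cccc3cc(Cl)ccc23)c(=O)[nH]1`: > 100000 nM
Compound 2 `N#Cc1cc2c(Oc3ccc(F)cc3OCCn3ccc(=O)[nH]c3=O)cc(F)cn2c1`: 50000 nM
Compound 3 `N#Cc1cc2c(Oc3ccccc3OCCn3ccc(=O)[nH]c3=O)cc(Cl)cc2o1`: > 100000 nM

Three compounds sharing the same core were tested in an ADME assay on MT2 cells (Homo sapiens) for cytotoxicity, read by MTT assay; on this read-out lower numbers stand for higher toxicity in this test and higher numbers for lower toxicity in this test. In this assay compound 1 gives > 100000 nM, a limit of the assay and not a measured number. Compound 1 thus sits at the limit of > 100000 nM in this assay, at which 2 of the 3 values shown sit. Compound 3 also gives only a limit in this assay, > 100000 nM. Compound 2 alone gives a number in this assay, 50000 nM. Compound 1 therefore stands among the values that show the lowest toxicity this assay can report, beside compound 3 and beyond what compound 2 shows.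

The next compound, compound 4 `Cc1ccc2c(Oc3ccccc3OCCn3ccc(=O)[nH]c3=O)cccc2c1`, has not yet been measured in this assay. It differs from compound 1 in one place: methyl in place of chloro on an aromatic carbon. Within the data shown here, no measured pair shows the effect of such a change, so the expectation rests on compound 1 alone. The step of a number no higher from compound 1 to compound 4 (the limit leaves the size open) is expected to be none beyond the scatter. Compound 4 is thus expected to give 100000 nM in this assay, with a range from 40000 nM to 200000 nM.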

Compound 4, half-maximal cytotoxic concentration: 40000 nM
Estimate against measurement, compound 4: 2.5-fold (0.40 log units) above; measured number inside the range.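

Methyl in place of chloro on this aromatic carbon, meta to a fused ring and para to a fused ring, gives the first readable step in this assay: an at least 2.5-fold lower number from compound 1 to compound 4 (0.39 log units; beyond the scatter). The earlier compounds shown here showed nothing about this place, and this step shows that what sits there can move the result towards higher toxicity in this test. The step is open on one side, and its full size cannot be read, because the value of compound 1 is a limit: the limit of > 100000 nM in this assay, at which 2 of the 4 values shown sit.

The compounds shown leave open how other groups at this place, such as an amine, a carboxylic acid or a longer alkyl chain, would read in this assay. They also leave open whether methyl in place of chloro would give a similar step on the core of compound 3.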